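A few compounds are considered here, and "the series" means these few. Any claim that something is new, unique, unknown or untested is made for them only; others in the source may bear on it.

In an ADME assay on Raji cells (Homo sapiens) for cytotoxicity, read by CellTiter-Glo and resazurin assay, with a stated time of 72 h (on this read-out higher numbers stand for an effect only at larger amounts of compound and lower numbers for an effect already at smaller amounts), compound 1, `CC(C)N(Cc1cccc(OCCCCCC(=O)O)c1)C(=O)c1ccc(-c2cccc(C(F)(F)F)c2)cc1`, gives > 26000 nM, which is a limit of the assay rather than a measured number. Compound 2, `CCOC(=O)CCCCCOc1cccc(CN(C(=O)c2ccc(-c3cnc(OC)nc3OC)cc2)C(C)C)c1`, gives > 26000 nM in this assay, again a limit and not a number. Compound 2 thus stands at the limit of > 26000 nM in this assay, at which 2 of the 2 values shown sit, so neither compound shows an effect within the range covered by the test. Compound 3, `CCOC(=O)CCCCCOc1cccc(CN(C(=O)c2ccc(-c3ccc4c(c3)OCCO4)cc2)C(C)C)c1`, has not yet been measured in this assay. It differs from compound 2 in one place: 2,3-dihydro-1,4-benzodioxin-6-yl in place of 2,4-dimethoxypyrimidin-5-yl on an aromatic carbon. Among the compounds with values here, no step between two measured compounds is available here, and both measured values are limits, so nothing shows whether a change of this kind moves the read-out at all. The expected step is a step that the limit leaves unreadable from compound 2 to compound 3, that is, no change beyond the usual scatter, since the data give no ground for expecting otherwise. Compound 3 is therefore expected to give about 30000 nM in this assay, within a range from 15000 nM to 60000 nM, and most likely the result will again be reported only as a limit.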

Compound 3, half-maximal effective concentration: > 24400 nM
Compound 3: no number, only a limit; the forecaster's own chance of this, stated with the estimate: 80%; the middle value does not contradict the limit.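

In this assay, within the data shown here, the results for compound 2 and compound 3 are both limits of the assay and not numbers, so no step between them can be read. The compounds shown leave open whether 2,3-dihydro-1,4-benzodioxin-6-yl in place of 2,4-dimethoxypyrimidin-5-yl moves the read-out at all, and at what concentration any effect would appear.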